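A few compounds are considered here, and "the series" means these few. Any claim that something is new, unique, unknown or untested is made for them only; others in the source may bear on it.

Measured compounds:
Compound 1 `Cc1ccc(=O)n(CCCCCC(=N)S)n1`: in a functional assay on the whole organism (stomach) with Rattus norvegicus as the target (on this read-out higher numbers stand for an effect only at larger amounts of compound and lower numbers for an effect already at smaller amounts), compound 1 gives > 100 mg/kg, a limit of the assay and not a number.
Compound 2 `Cc1ccc(=O)n(CCCCCCC(=N)S)n1`: in this assay compound 2 gives > 100 mg/kg, again a limit of the assay.
Compound 3 `N=C(S)CCCCCCn1nc(-c2ccccc2)ccc1=O`: in this assay compound 3 gives > 100 mg/kg, also a limit of the assay.

Compound 2 therefore stands only at a limit in this assay, and the two other values shown are limits as well, so no order among the three can be read. The step that the two limits leave unreadable from compound 1 to compound 2 is unreadable for the same reason, as is the step that the two limits leave unreadable from compound 2 to compound 3.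

Compound 4 `Cc1ccc(=O)n(CCCCC(=N)S)n1` differs from compound 2 by a group of 3 heavy atoms (1 carbon, 1 nitrogen, 1 sulfur; no ring) in place of a group of 5 heavy atoms (3 carbon, 1 nitrogen, 1 sulfur; no ring), on a saturated chain carbon, four bonds along the chain from an aromatic nitrogen. Within the data shown here, the only measured step on the same chain is the one from compound 1 to compound 2, and it gives no size. Because (the limit of > 100 mg/kg in this assay, at which 3 of the 3 values shown sit), the data hold no case in which a change of this chain brings the read-out off the limit. No step beyond the scatter in this assay is therefore expected for compound 4, and most likely only a limit will again be reported. Compound 4 is expected at about 150 mg/kg, with a range from 60 mg/kg to 400 mg/kg, the expected step being a step that the limit leaves unreadable from compound 2 to compound 4.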

Compound 4, dose for half-maximal effect: > 100 mg/kg
Compound 4: only a limit was reported (the forecaster's own chance of this, stated with the estimate: 85%); the middle value is on the limit's open side.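

In this assay compound 4 gives > 100 mg/kg, a limit of the assay and not a number. The steps from compound 2 to compound 4 and from compound 1 to compound 4 cannot be read: the limit of > 100 mg/kg in this assay, at which 4 of the 4 values shown sit.

The compounds shown leave open whether any change of chain or of the group on the shared core brings the read-out off this limit.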